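The compounds below may be only part of what the source reports. "The series", "measured", "known", "first", "only" and "open" are said of these compounds alone.

In a functional assay on the whole organism for inhibition, with Rattus norvegicus as the target, read by paw edema, with stated times of 30 min and 3 h, at a dose of 0.28 mmol/kg by the oral route (on this read-out lower numbers stand for less inhibition and higher numbers for more inhibition at the one dose given (going by the name of the read-out)), the measured compounds are:

compound 1, `CNC(=O)c1nc(-c2cc(OC)c(OC)c(OC)c2)n(-c2ccc(OC)cc2)n1`, with 74%
compound 2, `COc1ccc(-n2nc(C(=O)Nc3cccc(F)c3)nc2-c2cc(OC)c(OC)c(OC)c2)cc1`, with 72%
compound 3, `COc1ccc(-n2nc(C(=O)Nc3ccc(C(F)(F)F)cc3)nc2-c2cc(OC)c(OC)c(OC)c2)cc1`, with 65%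

Compound 3 sits at the lower edge of these three numbers, but the gaps to its neighbours, a number 7 percentage points lower from compound 2 to compound 3 (within the scatter) and a number 9 percentage points lower from compound 1 to compound 3 (within the scatter), both lie within the scatter, so the three compounds cannot be told apart on these readings. Compound 4, `COc1ccc(-n2nc(C(=O)Nc3ccc(O)cc3)nc2-c2cc(OC)c(OC)c(OC)c2)cc1`, differs from compound 3 in one place: hydroxy in place of trifluoromethyl on an aromatic carbon. Going by the values given here, no measured step exchanges one group for another on the aromatic ring that hangs from the amide-type nitrogen; the steps that exist, a number 2 percentage points lower from compound 1 to compound 2 (within the scatter), a number 9 percentage points lower from compound 1 to compound 3 (within the scatter) and a number 7 percentage points lower from compound 2 to compound 3 (within the scatter), all swap the whole group on that nitrogen, and none of them moves beyond the scatter. On that basis the step from compound 3 to compound 4 in this assay is expected to be a number 3 percentage points higher from compound 3 to compound 4 (within the scatter), that is, nothing beyond the scatter in either direction. Compound 4 is therefore estimated at 68% in this assay, with a range from 55% to 80%.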

Compound 4, a percentage reported as inhibition, in the whole organism at one dose (the size of the read-out at that dose, not a potency): 50%
Beside the measured number, compound 4's estimate is 18 percentage points above it; the measured number lies below the stated range.
By their numbers in this assay, from the lowest: compound 4; then compounds 3, 2 and 1 (each within the scatter of the next).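

In this assay, a change on the aromatic ring that hangs from the amide-type nitrogen moves the read-out: hydroxy in place of trifluoromethyl, para to a large group, gives a step beyond the scatter (a number 15 percentage points lower from compound 3 to compound 4 (beyond the scatter)), which none of the earlier swaps of the whole group on that nitrogen reached. The 4-hydroxyphenyl group also stands apart from 3-fluorophenyl (a number 22 percentage points lower from compound 2 to compound 4 (beyond the scatter)) and from methyl (a number 24 percentage points lower from compound 1 to compound 4 (beyond the scatter)), whereas methyl, 3-fluorophenyl and 4-(trifluoromethyl)phenyl cannot be told apart. No evidence on why hydroxy lowers the number is at hand.

As far as these compounds go, whether an amine or a carboxylic acid at that same place would read as low as hydroxy stays open. So does how this step would look at other doses.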